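Metabolic stability across a piperazine-capped series

A few compounds are considered here, and "the series" means these few. Any claim that something is new, unique, unknown or untested is made for them only; others in the source may bear on it.

Measured compounds:
compound 1 `c1ccc2c(c1)CN[C@@H](CN(CC[C@H]1CCCNC1)[C@H]1CCCc3cccnc31)C2` — 56%
compound 2 `CCN1CCN(CCCN(C[C@H]2Cc3ccccc3CN2)[C@H]2CCCc3cccnc32)CC1` — 19%
compound 3 `c1ccc2c(c1)CN[C@@H](CN(CCCCN1CCNCC1)[C@H]1CCCc3cccnc31)C2` — 96%

In an ADME assay on microsomes from liver (Mus musculus) for metabolic stability, read by LC-MS, with a stated time of 10 min, tested at 0.5 uM (on this read-out lower numbers stand for a less stable compound and higher numbers for a more stable compound), compound 3 gives 96%, the highest of the three numbers; compound 1 gives 56% and compound 2 gives 19%. The steps are all beyond the scatter: a number 40 percentage points higher from compound 1 to compound 3 (beyond the scatter), a number 37 percentage points lower from compound 1 to compound 2 (beyond the scatter) and a number 77 percentage points higher from compound 2 to compound 3 (beyond the scatter).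

Compound 4 `NC(=O)N1CCN(CCCN(C[C@H]2Cc3ccccc3CN2)[C@H]2CCCc3cccnc32)CC1` is not yet measured. It differs from compound 3 as follows: 4-carbamoylpiperazin-1-yl in place of (piperazin-1-yl)methyl on a saturated chain carbon, three bonds along the chain from an amine nitrogen.

The step that bears most directly on this change is a number 77 percentage points higher from compound 2 to compound 3 (beyond the scatter), where the piperazine nitrogen went from carrying an ethyl group to carrying a hydrogen and the number rose sharply. For the measured compounds named here, compound 4 carries a carbamoyl group on that nitrogen instead; no measured pair shows this particular substitution, so the size of its effect is not known. Because a number 77 percentage points higher from compound 2 to compound 3 (beyond the scatter) was large, a substituent on this nitrogen is expected to move the number downward, and the expected step is a number 26 percentage points lower from compound 3 to compound 4 (beyond the scatter), with wide uncertainty. Compound 4 is therefore estimated at 70%, within a range from 35% to 96%.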

Compound 4, percent of the compound remaining: 42%
Compound 4: middle estimate off by 28 percentage points, on the high side; low and high end bracket the measured number.
By their numbers in this assay, from the lowest: compound 2; then compound 4; then compound 1; then compound 3.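

In this assay, the change from compound 3 to compound 4 is not a change of cap alone: cut one bond further out, it reads 2-(piperazin-1-yl)ethyl to (4-carbamoylpiperazin-1-yl)methyl, so a number 54 percentage points lower from compound 3 to compound 4 (beyond the scatter) drop covers both chain length and the carbamoyl group. The cleaner reading of the cap is a number 23 percentage points higher from compound 2 to compound 4 (beyond the scatter) with carbamoyl in place of ethyl on an amine nitrogen in a ring, which shows that on this chain the substituent on that nitrogen alters the number and that carbamoyl sits above ethyl. Against the piperidin-3-yl side chain, the result is a number 14 percentage points lower from compound 1 to compound 4 (beyond the scatter) for (4-carbamoylpiperazin-1-yl)methyl in its place, so the carbamoyl-capped piperazine does not reach the number of that side chain.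

Still open, going by these compounds, is how much of the high number of compound 3 belongs to its longer chain and how much to its free piperazine nitrogen, which the unsubstituted piperazine on the shorter chain, the 4-carbamoylpiperazine on the longer chain or an acetyl group on that nitrogen would separate. Nothing at hand accounts for any of these steps.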